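This account rests on a few compounds, and the source may have more. Where it says the series, first, only, none or still open, it means among the compounds named here.

In a functional assay on MDA-MB-435 cells (Homo sapiens) for antiproliferative activity, read by sulforhodamine B assay (a lower number here means a stronger inhibitor, a higher number a weaker inhibitor), compound 1 (`COc1ccc2c(c1)CCCN2c1nc(C)nc2ccccc12`) gives 1.1 nM and compound 2 (`CSc1ccc(N(C)c2nc(C)nc3ccccc23)cc1`) gives 1.2 nM. Among the measured compounds shown here, these two values lie within the scatter of each other, so compound 1 shares the low end of the three numbers measured so far. Compound 3 (`COc1ccc(N(C)c2ncnc3ccccc23)cc1`) stands clearly higher, at 7.1 nM.

Compound 4 (`COc1ccc2c(c1)CCCN2c1ncnc2ccccc12`) departs from compound 1 at a single place: hydrogen in place of methyl on an aromatic carbon. This is hydrogen in place of methyl on an aromatic carbon, between two ring nitrogen atoms. For the measured compounds named here, no measured pair isolates this change, so the evidence is indirect. Compound 1 and compound 2 carry the methyl, whereas compound 3 has hydrogen there and gives 7.1 nM, although it also differs from both elsewhere. On that single comparison, a rise in the number beyond the scatter is expected in this assay, meaning a weaker inhibitor. The expected size of this change is a 5.5-fold higher number from compound 1 to compound 4 (0.74 log units; beyond the scatter). The estimate for compound 4 is 6 nM, with an expected range of 2.5 nM to 20 nM.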

Compound 4, half-maximal inhibitory concentration: 12.4 nM
The estimate for compound 4 lay 2.1-fold (0.32 log units) below the measured number, within the range that was stated.
By their numbers in this assay, from the lowest: compounds 1 and 2 (each within the scatter of the next); then compounds 3 and 4 (each within the scatter of the next).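

In this assay, putting hydrogen in place of methyl on this aromatic carbon, between two ring nitrogen atoms, gives an 11-fold higher number from compound 1 to compound 4 (1.05 log units; beyond the scatter), a large step. The earlier compounds shown here could only hint at this, as none of them differed from another at this one place alone. The pair now shows that, on the core of compound 1, this position is sensitive to the change from methyl to hydrogen, though nothing shown gives a measured reason for the step.

Among the compounds shown this position carries only methyl or hydrogen, so it remains open whether an ethyl group, a methoxy group or an amine there would give a number nearer that of compound 1 or compound 4. As far as these compounds go, it also remains open whether the same change gives a step of like size on the core of compound 2.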